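Methoxy on the Phenyl Ring and Expected Cytotoxicity

A few compounds are considered here, and "the series" means these few. Any claim that something is new, unique, unknown or untested is made for them only; others in the source may bear on it.

Within the data shown here, compound 1 `CSc1nc(NCCCCNc2ccnc3cc(Cl)ccc23)c(C#N)c(-c2ccccc2)n1` is the only compound here with a number in an ADME assay on HeLa cells (Homo sapiens) for cytotoxicity, read by microscopy (on this read-out lower numbers stand for higher toxicity in this test and higher numbers for lower toxicity in this test), where compound 1 gives 100000 nM. Compound 2 `CSc1nc(-c2ccccc2)c(C#N)c(N2CCN(c3ccnc4cc(Cl)ccc34)CC2)n1` reaches only a limit of the assay: in this assay compound 2 gives > 100000 nM. Compound 3 `COc1ccc(-c2nc(SC)nc(NCCCCNc3ccnc4cc(Cl)ccc34)c2C#N)cc1` has not yet been measured. It differs from compound 1 by methoxy in place of hydrogen on an aromatic carbon. Among the measured compounds shown here, no measured step of this kind is known here. The step of no change at the digits printed from compound 1 to compound 3 (within the scatter) is expected to stay within the usual scatter. A limit, as at the limit of > 100000 nM in this assay, at which 1 of the 2 values shown sits, remains possible. Compound 3 is therefore estimated at 100000 nM, between 50000 nM and 200000 nM.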

Compound 3, minimum cytotoxic concentration: 20000 nM
Compound 3: the middle estimate sits 5.0-fold (0.70 log units) above what was measured, outside the stated range (below it).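

The change from phenyl to 4-methoxyphenyl, para to a large group, gives a 5.0-fold lower number from compound 1 to compound 3 (0.70 log units; beyond the scatter) in this assay. Among these compounds, this is the first step measured at this position, and it shows that this read-out responds to a change there, with the methoxy compound on the side of higher toxicity in this test. Compound 2 stays a limit of the assay and enters no step: the limit of > 100000 nM in this assay, at which 1 of the 3 values shown sits.

As far as these compounds go, whether a hydroxy group, an amine or a longer alkoxy chain in the same place would also lower the number remains open. So does whether methoxy would do the same on the core of compound 2.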